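Swapping the Aryl Group on the Core of Compound 1

This account rests on a few compounds, and the source may have more. Where it says the series, first, only, none or still open, it means among the compounds named here.

Three compounds have been measured so far:
Compound 1, `O=C(O)Cc1sc(C(c2ccc(F)cc2)c2ccc(F)cc2)nc1-c1ccnc(N2CCCC2)c1`, gives 80%.
Compound 2, `O=C(O)Cc1sc(C(c2ccccc2)c2ccccc2)nc1-c1ccc(F)cc1`, gives 80%.
Compound 3, `O=C(O)Cc1sc(CS(=O)(=O)c2ccc(Cl)cc2)nc1-c1ccc(Cl)cc1`, gives 30%.

These numbers come from an in vitro functional assay on HEK285-7 cells for antagonist activity at prostaglandin D2 receptor 2 (Homo sapiens), read by BRET and beta-arrestin recruitment; on this read-out lower numbers stand for smaller maximal responses and higher numbers for larger maximal responses. Compound 1 stands level with compound 2 at the digits shown, and together they give the two highest of the three numbers; the gap between these two lies within the scatter of repeated measurements. Compound 3 lies furthest from compound 1, its number being lower by an amount well beyond that scatter.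

The unmeasured compound 4, `O=C(O)Cc1sc(C(c2ccc(F)cc2)c2ccc(F)cc2)nc1-c1cccc(F)c1`, differs from compound 1 in a single place: 3-fluorophenyl in place of 2-(pyrrolidin-1-yl)pyridin-4-yl on an aromatic carbon. Compound 4 thereby comes to resemble compound 2, which also carries a fluorine-bearing phenyl ring on the shared core next to a diaryl methyl group, and compound 2 gives 80%.

For the measured compounds named here, no step between two measured compounds covers this kind of exchange, so the expectation rests on the resemblance alone. In this assay the expected step of a number 5 percentage points lower from compound 1 to compound 4 (within the scatter) is small and not clearly beyond the scatter, in either direction. Compound 4 is therefore estimated to give 75%, with a likely range from 55% to 95%.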

Compound 4, largest response reached (reported as efficacy), in percent of the reference or control that the assay uses: 80%
Beside the measured number, compound 4's estimate is 5 percentage points below it; the measured number falls inside the stated range.
By their numbers in this assay, from the lowest: compound 3; then compounds 1, 2 and 4 (each within the scatter of the next).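

In this assay, placing 3-fluorophenyl in place of 2-(pyrrolidin-1-yl)pyridin-4-yl on this aromatic carbon gives no change at the digits printed from compound 1 to compound 4 (within the scatter), the first single-place comparison available at this position. For this pair, the five-membered non-aromatic ring and both nitrogen atoms of the departing group can therefore be exchanged for a smaller ring of carbon only, together with a fluorine, without a change in the maximal response that can be told from the scatter. Nothing available explains why the response holds across this exchange.

Because the whole group changes at once, this pair cannot separate the contribution of the pyrrolidine ring from that of the pyridine nitrogen, and it cannot say whether the fluorine on the new ring matters, a question that a plain phenyl ring would address. It also leaves open whether this position needs a ring at all, as the compounds shown say nothing about how a simple amine, a carboxylic acid or a short alkyl chain would behave on this carbon.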